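The compounds below may be only part of what the source reports. "The series", "measured", "known", "first", "only" and "open" are said of these compounds alone.

Working notes on the series. Compound 3 `CC(C)c1c(C(=O)N2CCC[C@H](c3ccccc3)C2)nn(-c2ccc(F)cc2)c1OC[C@@H](O)C[C@@H](O)CC(=O)O` stands second highest of the three numbers measured in an assay on microsomes from liver for inhibition of 3-hydroxy-3-methylglutaryl-coenzyme A reductase (Rattus norvegicus); on this read-out lower numbers stand for stronger inhibition and higher numbers for weaker inhibition: compound 3 gives 4.8 nM, with compound 1 `CC(C)c1c(C(=O)NCc2ccccc2)nn(-c2ccc(F)cc2)c1OC[C@@H](O)C[C@@H](O)CC(=O)O` nearest at 3.8 nM and compound 2 `Cc1ccc(CNC(=O)c2nn(-c3ccc(F)cc3)c(OC[C@@H](O)C[C@@H](O)CC(=O)O)c2C(C)C)cc1` furthest at 15 nM. The step from compound 1 to compound 3 is a 1.3-fold higher number from compound 1 to compound 3 (0.10 log units; within the scatter), so the two are not separated; the step from compound 2 to compound 3 is a 3.1-fold lower number from compound 2 to compound 3 (0.49 log units; beyond the scatter).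

Compound 4 `CC(C)c1c(C(=O)NCc2cccc(Cl)c2)nn(-c2ccc(F)cc2)c1OC[C@@H](O)C[C@@H](O)CC(=O)O` is not yet measured. Its change from compound 3: (3-chlorobenzyl)amino in place of 3-phenylpiperidin-1-yl on a carbonyl carbon. Among the compounds with values here, two measured steps bear on it. The replacement of benzylamino by 3-phenylpiperidin-1-yl, a 1.3-fold higher number from compound 1 to compound 3 (0.10 log units; within the scatter), shows that the two amide substituents are interchangeable within scatter, so the return to a benzylamino type is expected to cost little. Adding a methyl on an aromatic carbon, a 3.9-fold higher number from compound 1 to compound 2 (0.60 log units; beyond the scatter), gave a modest rise; no measured compound carries chlorine on the benzyl ring, so the effect of the chlorine is not known here. Compound 4 is therefore expected to land near compound 1 or somewhat higher, a step of a 1.3-fold higher number from compound 3 to compound 4 (0.10 log units; within the scatter). Compound 4 is estimated at 6 nM, with a range from 2 nM to 20 nM.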

Compound 4, half-maximal inhibitory concentration: 5.4 nM
Beside the measured number, compound 4's estimate is 1.1-fold (0.05 log units) above it, within the range that was stated.
By their numbers in this assay, from the lowest: compounds 1, 3 and 4 (each within the scatter of the next); then compound 2.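

In this assay the (3-chlorobenzyl)amino group, with 1 hydrogen-bond donor, and 3-phenylpiperidin-1-yl, with 0 hydrogen-bond donors, are not separated on this carbonyl carbon (a 1.1-fold higher number from compound 3 to compound 4 (0.05 log units; within the scatter)). The added chloro on the benzyl group also stays within the scatter (a 1.4-fold higher number from compound 1 to compound 4 (0.15 log units; within the scatter)), so a substituent on that ring does not always move the number beyond it, as the methyl of compound 2 did. The exchange of 4-methylphenyl for 3-chlorophenyl recovers most of that step (a 2.8-fold lower number from compound 2 to compound 4 (0.44 log units; beyond the scatter)), but it changes both the substituent and its place on the ring.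

(3-Methylbenzyl)amino and (4-chlorobenzyl)amino would separate those two changes. Whether a larger group such as (3-bromobenzyl)amino is accommodated here remains open, and nothing available explains these steps.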